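Cyclopropylmethoxy for allyloxy in the series

A few compounds are considered here, and "the series" means these few. Any claim that something is new, unique, unknown or untested is made for them only; others in the source may bear on it.

In a functional assay on the whole organism (strain Sprague-Dawley) for inhibition, with Rattus norvegicus as the target, with a stated time of 10 min (on this read-out higher numbers stand for an effect only at larger amounts of compound and lower numbers for an effect already at smaller amounts), so far
compound 1 `CC(C)Oc1ccccc1-c1ncc(C(=O)O)c(=O)[nH]1` gives 0.8 mg/kg
compound 2 `C=CCOc1ccccc1-c1ncc(C(=O)O)c(=O)[nH]1` gives 0.5 mg/kg

Compound 2 at 0.5 mg/kg lies within the scatter of compound 1 at 0.8 mg/kg and the two are not separated. Compound 3 `O=C(O)c1cnc(-c2ccccc2OCC2CC2)[nH]c1=O` carries cyclopropyl in place of vinyl on a saturated chain carbon bound to an oxygen on an aromatic ring. Within the data shown here, the one measured step bearing on this, with allyl in place of isopropyl on an oxygen on an aromatic ring, is a 1.6-fold lower number from compound 1 to compound 2 (0.20 log units; within the scatter) and it is small. No step beyond the scatter is therefore expected in this assay and the estimated step is a 1.2-fold higher number from compound 2 to compound 3 (0.08 log units; within the scatter) with no firm direction. For compound 3 the expected value is 0.6 mg/kg (estimated range 0.25 mg/kg to 1.5 mg/kg).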

Compound 3, dose for 50% inhibition: 0.1 mg/kg
The estimate for compound 3 lay 6.0-fold (0.78 log units) above the measured number, outside the stated range (below it).
By their numbers in this assay, from the lowest: compound 3; then compounds 2 and 1 (each within the scatter of the next).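

The group on the oxygen on the aromatic ring can shift the dose in this assay, which compounds 1 and 2 alone did not show. Cyclopropyl in place of vinyl on the saturated chain carbon gives a step beyond the scatter (a 5.0-fold lower number from compound 2 to compound 3 (0.70 log units; beyond the scatter)), and cyclopropylmethyl in place of isopropyl gives another (an 8.0-fold lower number from compound 1 to compound 3 (0.90 log units; beyond the scatter)). Nothing available accounts for this gain.

Going by these compounds, whether the three-membered ring itself matters remains open. Cyclobutylmethoxy or a longer chain such as n-butoxy at this place would test that.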